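A few compounds are considered here, and "the series" means these few. Any claim that something is new, unique, unknown or untested is made for them only; others in the source may bear on it.

Working notes on the series. The shared core is shown by compound 1 `Cc1cccc(Oc2ccc(C#N)cc2S(=O)(=O)NC(=O)NC(C)C)c1`, which in a functional assay on HEK293 cells for antagonist activity at thromboxane A2 receptor (Homo sapiens), read by fluorescence and calcium flux (a higher number here means a weaker inhibitor, a lower number a stronger inhibitor), gives 2380 nM. Compound 2 `CCCCCNC(=O)NS(=O)(=O)c1cc(C#N)ccc1Oc1cccc(C)c1` gives 1330 nM in this assay. Within the data shown here, the single measured step, a 1.8-fold lower number from compound 1 to compound 2 (0.25 log units; within the scatter), is within the scatter, so compound 2 holds the lowest of the two numbers without separating from compound 1.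

Compound 3 `CCCCCNC(=O)NS(=O)(=O)c1cc(C#N)ccc1Oc1ccc(F)cc1` is not yet measured. Its change from compound 2 sits on the oxygen on the aromatic ring: 4-fluorophenyl in place of 3-methylphenyl on an oxygen on an aromatic ring. Among the measured compounds shown here, no measured step bears on this part of the molecule; the only step recorded, a 1.8-fold lower number from compound 1 to compound 2 (0.25 log units; within the scatter), concerns the substituent on the amide-type nitrogen, which compound 2 and compound 3 share as pentyl. The data therefore give no direction for the change at the ether-linked ring, and the default expectation is a step no larger than the scatter, with wide uncertainty. For compound 3 the expected step, a 1.1-fold higher number from compound 2 to compound 3 (0.05 log units; within the scatter), is taken as inside the scatter. Compound 3 is estimated at 1500 nM in this assay, with a range of 450 nM to 5000 nM.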

Compound 3, half-maximal inhibitory concentration: 9430 nM
Compound 3: middle estimate off by 6.3-fold (0.80 log units), on the low side; the measured number lies above the stated range.
By their numbers in this assay, from the lowest: compounds 2 and 1 (each within the scatter of the next); then compound 3.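

In this assay, among these compounds, the ring on the ether oxygen is the first place where a change separates from the scatter: a 7.1-fold higher number from compound 2 to compound 3 (0.85 log units; beyond the scatter), whereas the change on the amide-type nitrogen gives a 1.8-fold lower number from compound 1 to compound 2 (0.25 log units; within the scatter). The 3-methylphenyl and 4-fluorophenyl groups match in heavy atoms, hydrogen-bond donors, hydrogen-bond acceptors and net charge, so these computed counts do not account for the difference between compound 2 and compound 3, and the ring's substitution alone is enough to move the number beyond the scatter. No measurement in hand bears on the reason for this step.

The step from compound 2 to compound 3 changes both the substituent and its ring position, so the effect of swapping methyl for fluorine cannot be told apart from that of moving the substituent; 3-fluorophenyl and 4-methylphenyl, with unsubstituted phenyl as a reference, would separate the two. From the compounds shown here alone, it also remains open whether the same ring change gives a step of similar size with isopropyl or a longer chain such as heptyl on the amide-type nitrogen, since pentyl is the only substituent there for which this change can be read.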